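Isopropyl for cyclobutyl: expectation for compound 4

The source may hold more compounds than are shown below. What is called first, only, known or untested is meant among the compounds shown, and "the series" means these compounds.

Compound 1, `CCCc1cc(N)c2cc(NC(=O)c3ccc(-c4ccc(Cl)cc4)cc3)ccc2n1`: 75 nM
Compound 2, `Nc1cc(C2CCC2)nc2ccc(NC(=O)/C=C/c3ccc(C(F)(F)F)cc3)cc12`: 250 nM
Compound 3, `CCCc1cc(N2CCC2)c2cc(NC(=O)/C=C/c3ccc(C(F)(F)F)cc3)ccc2n1`: 2500 nM

All three were measured in a functional assay on HEK293 cells for activation of melanin-concentrating hormone receptor 1 (Homo sapiens), read by inositol phosphate accumulation; a higher number here means that more compound is needed for the effect, a lower number that less compound is needed. Compound 2 stands second highest of the three: compound 1 gives a lower number and compound 3 a higher one, and both gaps lie beyond the scatter.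

Compound 4, `CC(C)c1cc(N)c2cc(NC(=O)/C=C/c3ccc(C(F)(F)F)cc3)ccc2n1`, differs from compound 2 by isopropyl in place of cyclobutyl on an aromatic carbon. Among the compounds with values here, no pair of measured compounds isolates this change, so the expectation rests only on the closeness of the two groups: a step no larger than the scatter is expected, if anything toward a slightly higher number. The expected step is a 1.2-fold higher number from compound 2 to compound 4 (0.08 log units; within the scatter). Compound 4 is accordingly estimated at 300 nM, with a range from 120 nM to 750 nM.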

Compound 4, half-maximal effective concentration: 160 nM
Beside the measured number, compound 4's estimate is 1.9-fold (0.27 log units) above it; low and high end bracket the measured number.
By their numbers in this assay, from the lowest: compound 1; then compounds 4 and 2 (each within the scatter of the next); then compound 3.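

In this assay, within the data shown here, the step of a 1.6-fold lower number from compound 2 to compound 4 (0.19 log units; within the scatter) gives the first single-change reading: at the aromatic carbon next to the ring nitrogen, replacing cyclobutyl with isopropyl leaves the number within the scatter. The four-membered ring is therefore not required at this position in this comparison. No available measurement explains the result.

Still open, going by these compounds, is how this position responds to groups of a different kind, such as methoxy, phenyl or a dimethylamino group. On these data alone, whether the same swap holds with the other amide side chain of compound 1 also remains open.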